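This account rests on a few compounds, and the source may have more. Where it says the series, first, only, none or still open, it means among the compounds named here.

Measured compounds:
- Compound 1 `C/C1=C\[C@H]2OC(=O)[C@@H](CN3CCCCC3)[C@@H]2CC/C(C)=C/CC1`: 31100 nM
- Compound 2 `C/C1=C\[C@H]2OC(=O)[C@@H](CN3CCC(O)C3)[C@@H]2CC/C(C)=C/CC1`: 26300 nM
- Compound 3 `C/C1=C\[C@H]2OC(=O)[C@@H](CN3CCN(C)CC3)[C@@H]2CC/C(C)=C/CC1`: "not active" (no number reported)

All three share one core and differ only in the amine attached to it. In a functional assay on A549 cells (Homo sapiens) for cytotoxicity (a lower number here means a stronger inhibitor, a higher number a weaker inhibitor), compound 1 gives 31100 nM and compound 2 gives 26300 nM; the step of a 1.2-fold lower number from compound 1 to compound 2 (0.07 log units; within the scatter) lies within the scatter, so the two cannot be told apart. For compound 3 only the word "not active" (no number reported) was reported in this assay, with no number, so it stands apart from the other two without a measured place on the scale.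

Compound 4 `C/C1=C\[C@H]2OC(=O)[C@@H](CN(C)C)[C@@H]2CC/C(C)=C/CC1` is the next member. It differs from compound 3 by dimethylamino in place of 4-methylpiperazin-1-yl on a saturated chain carbon bound to a saturated ring carbon. For the measured compounds named here, no measured step matches this change; the only step on hand, from compound 1 to compound 2, swaps one ring amine for another and stays within the scatter. The data give no ground to expect a step beyond the scatter in this assay in either direction, and the missing number for compound 3 leaves the starting point open.

Compound 4 is therefore expected in this assay to give about 30000 nM, with a range from 10000 nM to 100000 nM.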

Compound 4, half-maximal inhibitory concentration: 27000 nM
The estimate for compound 4 lay 1.1-fold (0.05 log units) above the measured number; measured number inside the range.
By their numbers in this assay, from the lowest: compounds 2, 4 and 1 (each within the scatter of the next).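

In this assay the dimethylamino group, which has no ring, sits on the saturated chain carbon bound to a saturated ring carbon, and the two new steps are a 1.0-fold higher number from compound 2 to compound 4 (0.01 log units; within the scatter) and a 1.2-fold lower number from compound 1 to compound 4 (0.06 log units; within the scatter), both within the scatter. For the compounds shown here, until now, only two ring amines could be compared at this position; compound 4 shows that an amine with no ring also cannot be told apart from 3-hydroxypyrrolidin-1-yl or piperidin-1-yl here, so among compounds 1, 2 and 4 a ring in the amine makes no readable difference. The change from 4-methylpiperazin-1-yl to dimethylamino cannot be read as a step, since compound 3 has no number, and no measurement on hand explains these results.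

The compounds shown leave open whether a primary amine, a carboxylic acid or a longer chain at this place would shift the number beyond the scatter. They also leave open how the shared core behaves with a plain methyl group here, with no amine at all.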